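Iodo to cyano on the pendant phenyl ring and solubility

The source may hold more compounds than are shown below. What is called first, only, known or untested is meant among the compounds shown, and "the series" means these compounds.

compound 1 `CCc1ccc(-c2nc3c(c(C)nn3-c3ccccc3)c(-c3ccccc3C#N)c2C#N)cc1`: 2400 nM
compound 2 `CCc1ccc(-c2nc3c(c(C)nn3-c3ccccc3)c(-c3ccccc3I)c2C#N)cc1`: 8500 nM
compound 3 `Cc1nn(-c2ccccc2)c2nc(-c3ccc(I)cc3)c(C#N)c(-c3ccccc3O)c12`: 1500 nM

In a physicochemical assay for solubility, read by spectrophotometry, in phosphate buffer, with a stated time of 18 h, at pH 7.4 (on this read-out higher numbers stand for higher solubility and lower numbers for lower solubility), compound 2 gives 8500 nM and compound 1 gives 2400 nM; the change between them, (cyano in place of iodo on an aromatic carbon), made a 3.5-fold lower number from compound 2 to compound 1 (0.55 log units; beyond the scatter). Compound 3 gives 1500 nM in this assay, a lower number than compound 2, while the difference between the cores of compound 3 and compound 2 is not broken down here. Compound 4 `Cc1nn(-c2ccccc2)c2nc(-c3ccc(C#N)cc3)c(C#N)c(-c3ccccc3O)c12` carries the change (cyano in place of iodo on an aromatic carbon), the same kind of change as in compound 1, but here para to a large group rather than ortho to a large group. A step of similar direction, a 2.5-fold lower number from compound 3 to compound 4 (0.40 log units; beyond the scatter), is expected for compound 4, because the same change gave a 3.5-fold lower number from compound 2 to compound 1 (0.55 log units; beyond the scatter). Compound 4 is therefore estimated at 600 nM in this assay, between 250 nM and 1500 nM.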

Compound 4, solubility: 1700 nM
Estimate against measurement, compound 4: 2.8-fold (0.45 log units) below, and the stated range ends below it.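

In this assay the change from iodo to cyano gave a 3.5-fold lower number from compound 2 to compound 1 (0.55 log units; beyond the scatter) on one core but a 1.1-fold higher number from compound 3 to compound 4 (0.05 log units; within the scatter) on the other, where the change sits para to a large group, so the step did not carry over between these two cores. These two pairs differ both in core and in the place of the change, and they do not show which of the two separates the steps. Nothing measured here gives a reason for the difference between the steps.

From the compounds shown here alone, it stays open how an amine or a carboxylic acid in the same place would read on either core. Going by these compounds, it is also open what the same change would give on a third core.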